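A urea returned to an amide, stripped of its substituents

The source may hold more compounds than are shown below. What is called first, only, known or untested is meant among the compounds shown, and "the series" means these compounds.

Two compounds share one core and differ only in the group attached to the carbonyl carbon of the amide-type linker. Compound 1 `COc1cc(-c2nn(-c3cccc(NC(=O)c4ccc(Cl)c(C(F)(F)F)c4)c3)cc2-c2ccncc2)ccc1Cl` carries a 4-chloro-3-(trifluoromethyl)phenyl there and, in a functional assay on A498 cells (Homo sapiens) for inhibition, read by sulforhodamine B assay, with a stated time of 48 h (on this read-out higher numbers stand for weaker inhibition of growth and lower numbers for stronger inhibition of growth), compound 1 gives 22700 nM. Going by the values given here, compound 2 `COc1cc(-c2nn(-c3cccc(NC(=O)Nc4ccc(Cl)c(C(F)(F)F)c4)c3)cc2-c2ccncc2)ccc1Cl` carries a (4-chloro-3-(trifluoromethyl)phenyl)amino instead, and in this assay compound 2 gives 6970 nM, the lower of the two numbers; the step of a 3.3-fold lower number from compound 1 to compound 2 (0.51 log units; beyond the scatter) is the only measured step available.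

Compound 3 `COc1cc(-c2nn(-c3cccc(NC(=O)c4ccccc4)c3)cc2-c2ccncc2)ccc1Cl` is the next compound to be measured. Its change from compound 2 is phenyl in place of (4-chloro-3-(trifluoromethyl)phenyl)amino on a carbonyl carbon. Among the compounds with values here, this change undoes the amino linker that compound 2 gained over compound 1 and at the same time removes the chloro and trifluoromethyl groups, for which no step has been measured. Going by these compounds, only the measured step of a 3.3-fold lower number from compound 1 to compound 2 (0.51 log units; beyond the scatter) bears on the expectation, and read in reverse it points toward a higher number; the effect of losing the two substituents is unknown, so the range must be wide. For compound 3 the estimated value in this assay is 35000 nM, within 10000 nM to 120000 nM, corresponding to an expected step of a 5.0-fold higher number from compound 2 to compound 3 (0.70 log units; beyond the scatter).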

Compound 3, concentration for total growth inhibition: 3140 nM
The estimate for compound 3 lay 11-fold (1.05 log units) above the measured number, and the stated range ends above it.
By their numbers in this assay, from the lowest: compound 3; then compound 2; then compound 1.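

In this assay the clearest comparison keeps the amide linker and changes only the group on the carbonyl carbon: removing the chloro and trifluoromethyl groups from that ring gives a 7.2-fold lower number from compound 1 to compound 3 (0.86 log units; beyond the scatter) and shows that, with this linker, neither substituent is needed to reach the lower number. The result also changes how the earlier gain from the amino linker reads, since the step of a 2.2-fold lower number from compound 2 to compound 3 (0.35 log units; beyond the scatter) places the plain phenyl amide below the urea compound, though this step changes the linker and the substituents together and cannot assign the drop to either one. Nothing measured here explains why the simpler group gives the lower number.

The compounds shown leave open whether a phenylamino group on the same carbonyl carbon would lower the number further, which would show if the amino linker still helps on an unsubstituted ring. They also leave open whether the chloro or the trifluoromethyl group contributes more to the higher number, a question that a phenyl carrying only one of the two could address.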